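The source may hold more compounds than are shown below. What is called first, only, known or untested is meant among the compounds shown, and "the series" means these compounds.

Measured compounds:
- compound 1, `O=C1/C(=C/c2ccccc2C(F)(F)F)CCc2ccc(O)cc21`: 1020 nM
- compound 2, `O=C1/C(=C/c2ccccc2OC(F)(F)F)CCc2ccc(O)cc21`: 420 nM

Both were run in a functional assay on RAW264.7 cells (Mus musculus) for inhibition; a higher number here means a weaker inhibitor, a lower number a stronger inhibitor. For the measured compounds named here, compound 2 has the lowest number of the two; its nearest neighbour is compound 1, and the single measured step, a 2.4-fold lower number from compound 1 to compound 2 (0.39 log units; beyond the scatter), is a modest one.

Compound 3, `O=C1/C(=C/c2ccccc2Br)CCc2ccc(O)cc21`, is not yet measured. It differs from compound 2 by bromo in place of trifluoromethoxy on an aromatic carbon. Going by the values given here, the only measured step that bears on it is the exchange at the same aromatic carbon from compound 1 to compound 2, which was modest and beyond the scatter; no step involving bromo, or any other halogen, has been measured, so the direction of the new exchange rests on that single comparison alone. A step no larger than that one is expected, and the estimate places it as a 1.5-fold higher number from compound 2 to compound 3 (0.19 log units; within the scatter). For compound 3 the expected value in this assay is 650 nM, with a range from 250 nM to 1700 nM.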

Compound 3, half-maximal inhibitory concentration: 500 nM
Compound 3: middle estimate off by 1.3-fold (0.11 log units), on the high side; measured number inside the range.
By their numbers in this assay, from the lowest: compounds 2 and 3 (each within the scatter of the next); then compound 1.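

Within this assay the exchange on this aromatic carbon of trifluoromethoxy, with 5 heavy atoms, for bromo, with 1 heavy atom, gives a 1.2-fold higher number from compound 2 to compound 3 (0.08 log units; within the scatter) and so does not separate the two groups. Set against trifluoromethyl, bromo gives a 2.0-fold lower number from compound 1 to compound 3 (0.31 log units; beyond the scatter) and so, among these three compounds, trifluoromethyl alone stands apart with the higher number, with neither compound 2 nor compound 3 going against that. No measurement on hand accounts for these differences.

Open, from the compounds shown here alone, is whether chloro, methoxy, an amine or a carboxylic acid on the same carbon would stay with compound 2 and compound 3 or with compound 1. Also open, going by these compounds, is whether bromo and trifluoromethoxy would remain inseparable on another carbon of the same ring.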